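The source may report more compounds than this note shows. Statements on the series, on what has been measured and on what is new or still open speak of the compounds shown alone.

Measured compounds in an assay on microsomes from liver for inhibition of 3-hydroxy-3-methylglutaryl-coenzyme A reductase (Rattus norvegicus), read by scintillation counting, with stated times of 0.5 h and 0.75 h; on this read-out lower numbers stand for stronger inhibition and higher numbers for weaker inhibition:

Compound 1, `COc1ccc(CNC(=O)c2nc(-c3ccc(F)cc3)n(CC[C@@H](O)C[C@@H](O)CC(=O)O)c2C2CC2)cc1`, gives 1.2 nM.
Compound 2, `O=C(O)C[C@H](O)C[C@H](O)CCn1c(-c2ccc(F)cc2)nc(C(=O)NCc2ccccc2)c1C1CC1`, gives 1.4 nM.
Compound 3, `O=C(O)C[C@H](O)C[C@H](O)CCn1c(-c2ccc(F)cc2)nc(C(=O)NCc2cccc(F)c2)c1C1CC1`, gives 1.2 nM.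

Compound 3 stands level with compound 1 at the digits shown, and its difference from compound 2 is a 1.2-fold lower number from compound 2 to compound 3 (0.07 log units; within the scatter), so all three numbers sit within the scatter of one another. The step from compound 3 to compound 4, `COc1ccccc1CNC(=O)c1nc(-c2ccc(F)cc2)n(CC[C@@H](O)C[C@@H](O)CC(=O)O)c1C1CC1`, is 2-methoxyphenyl in place of 3-fluorophenyl on a saturated chain carbon bound to an amide-type nitrogen. Within the data shown here, two measured steps bear on it: a 1.2-fold higher number from compound 1 to compound 2 (0.07 log units; within the scatter) and no change at the digits printed from compound 1 to compound 3 (within the scatter), both within the scatter, showing that removing methoxy from the aromatic ring or replacing the whole 4-methoxyphenyl by 3-fluorophenyl on the saturated chain carbon bound to the amide-type nitrogen left this assay unmoved. Since a methoxyphenyl group in compound 1 already gives 1.2 nM, the 2-methoxyphenyl of compound 4 is expected to give a step of a 1.2-fold higher number from compound 3 to compound 4 (0.07 log units; within the scatter), that is no change beyond the scatter. The estimate for compound 4 in this assay is 1.4 nM, with a range from 0.6 nM to 3.5 nM.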

Compound 4, half-maximal inhibitory concentration in the 3-hydroxy-3-methylglutaryl-coenzyme A reductase assay: 7 nM
The estimate for compound 4 lay 5.0-fold (0.70 log units) below the measured number; the whole stated range lies below it.
By their numbers in the 3-hydroxy-3-methylglutaryl-coenzyme A reductase assay, from the lowest: compounds 1, 3 and 2 (each within the scatter of the next); then compound 4.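

In the 3-hydroxy-3-methylglutaryl-coenzyme A reductase assay the place of the methoxy on the phenyl ring proves to matter: 4-methoxyphenyl and 2-methoxyphenyl are not interchangeable (a 5.8-fold higher number from compound 1 to compound 4 (0.77 log units; beyond the scatter)). Among these compounds, the 2-methoxyphenyl also separates compound 4 from the unsubstituted phenyl (a 5.0-fold higher number from compound 2 to compound 4 (0.70 log units; beyond the scatter)) and from the 3-fluorophenyl (a 5.8-fold higher number from compound 3 to compound 4 (0.77 log units; beyond the scatter)), so this group on a saturated chain carbon bound to an amide-type nitrogen is not as free to vary as the earlier compounds suggested. In a physicochemical assay for lipophilicity, using the shake flask method, at pH 7.4 (on this read-out higher numbers stand for higher lipophilicity and lower numbers for lower lipophilicity), compound 3 gives 0.51 and compound 4 gives 0.16 but this single pair cannot tie the distribution coefficient to the inhibition numbers.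

From the compounds shown here alone, it remains open whether the weaker number belongs to the methoxy itself or would also appear with 2-fluorophenyl or 2-methylphenyl. A 3-methoxyphenyl is also needed to show how far the effect depends on the group's place on the ring.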